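From compound 3 to compound 4: a larger group enters

The source may report more compounds than this note shows. Statements on the series, on what has been measured and on what is new or still open speak of the compounds shown alone.

In a physicochemical assay for lipophilicity, using the shake flask method, measured as octanol-water partition, at pH 7.4 (a higher number here means a more lipophilic compound, a lower number a more polar compound), compound 1 `CC(=O)N[C@@H]1CCC[C@H](C(=O)Nc2cc(-c3cnc(C)n3C(C)C)ccn2)C1` gives 1.9, compound 2 `CC(=O)N[C@@H]1CCC[C@H](C(=O)Nc2cc(-c3cnn4c3CCCC4)ccn2)C1` gives 2.4 and compound 3 `CC(=O)N[C@@H]1CCC[C@H](C(=O)Nc2cc(-c3cnn(C)c3C)c(Cl)cn2)C1` gives 2.6. Compound 3 thus stands clearly above compound 1, while its gap to compound 2 lies within the scatter. Compound 4 `CC(=O)N[C@@H]1CCC[C@H](C(=O)Nc2cc(-c3cnc4n3CCCC4)c(Cl)cn2)C1` differs from compound 3 in one place, ortho to a chloro group: a group of 9 heavy atoms (7 carbon, 2 nitrogen; one five-membered aromatic ring with 2 hetero atoms, one six-membered non-aromatic ring with 1 hetero atom) in place of a group of 7 heavy atoms (5 carbon, 2 nitrogen; one five-membered aromatic ring with 2 hetero atoms), on an aromatic carbon, with the 1,5-dimethyl-1H-pyrazol-4-yl group leaving. For the measured compounds named here, one measured step bears on this, a number 0.50 log units higher from compound 1 to compound 2 (beyond the scatter), and it also brought in a group with a six-membered non-aromatic ring. It is only a partial guide: it was measured without the chloro group, and the five-membered ring entering here has its nitrogens arranged as in compound 1, not as in compound 2. Compound 1, with that arrangement, stands at 1.9, so no step beyond the scatter is expected in this assay. The expected change is a number 0.20 log units lower from compound 3 to compound 4 (within the scatter). Compound 4 is estimated at 2.4, with an expected range from 2 to 2.8.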

Compound 4, distribution coefficient: 2.7
For compound 4 the middle estimate is 0.30 log units below the measured one; low and high end bracket the measured number.
By their numbers in this assay, from the lowest: compound 1; then compounds 2, 3 and 4 (each within the scatter of the next).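

In this assay, swapping the 1,5-dimethyl-1H-pyrazol-4-yl group for the larger group with its added six-membered non-aromatic ring, on the aromatic carbon ortho to a chloro group, gives a number 0.10 log units higher from compound 3 to compound 4 (within the scatter). So in this pair, a larger group at this position comes with no change beyond the scatter, while the counts of hydrogen-bond donors and acceptors stay the same. No measurement at hand explains this outcome.

For the compounds shown here, what the chloro group itself contributes stays open, since no pair here differs in that place alone. Also open, from the compounds shown here alone, is how the number would respond at this position to a group carrying an amine or a carboxylic acid on the six-membered non-aromatic ring, since every group here has only carbon and ring nitrogens.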